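Working notes: changing the fluorinated ether of compound 2

The compounds below may be only part of what the source reports. "The series", "measured", "known", "first", "only" and "open" are said of these compounds alone.

Measured so far in an ADME assay, at pH 3; a higher number here means that the compound lasts longer, a lower number that the compound disappears faster:
- compound 1 `COc1cnc(C[S+]([O-])c2nc3cc(OC(F)F)ccc3[nH]2)cc1OC`: 0.283 h
- compound 2 `COc1cnc(C[S+]([O-])c2nc3cc(OCC(F)(F)F)ccc3[nH]2)c(C)c1OC`: 0.167 h
- compound 3 `COc1ccnc(C[S+]([O-])c2nc3cc(OCC(F)(F)F)ccc3[nH]2)c1C`: 0.0833 h

Compound 2 stands in the middle of these three numbers, but within the scatter of both compound 1 and compound 3, so the set gives it no clear rank.

The next compound is compound 4 `COc1cnc(C[S+]([O-])c2nc3cc(OC(F)(F)C(F)F)ccc3[nH]2)c(C)c1OC`, and the change is 1,1,2,2-tetrafluoroethyl in place of 2,2,2-trifluoroethyl on an oxygen on an aromatic ring. In short, 2,2,2-trifluoroethoxy gives way to 1,1,2,2-tetrafluoroethoxy.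

Among the measured compounds shown here, only one clean step has been measured, a 2.0-fold lower number from compound 2 to compound 3 (0.30 log units; within the scatter). It is a change elsewhere in the molecule, hydrogen in place of methoxy on an aromatic carbon, so it shows only how small a single change can be in this assay and says nothing direct about this oxygen. Compound 1, at 0.283 h, also has a different group on that oxygen, but it differs from compound 2 in other places too, so it cannot isolate the change. For the measured compounds named here, no measured pair isolates this change.

No direction can be argued from these data, and no step beyond the scatter is expected. The estimated step is a 1.2-fold higher number from compound 2 to compound 4 (0.08 log units; within the scatter). For compound 4 the expected value is 0.2 h, with an estimated range of 0.1 h to 0.4 h.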

Compound 4, half-life: 0.333 h
Estimate against measurement, compound 4: 1.7-fold (0.22 log units) below; the range from low to high includes it.
By their numbers in this assay, from the lowest: compounds 3, 2, 1 and 4 (each within the scatter of the next, the first and the last beyond it).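

Among the compounds shown here, compound 2 and compound 4 form the first measured pair that isolates the group on this oxygen. In this assay, 1,1,2,2-tetrafluoroethyl in place of 2,2,2-trifluoroethyl gives a 2.0-fold higher number from compound 2 to compound 4 (0.30 log units; within the scatter) and this places the exchange of these two fluorinated groups within the usual scatter, so the pair shows no clear effect of this change at this position, and the half-life can be read as unchanged. The other clean step, a 2.0-fold lower number from compound 2 to compound 3 (0.30 log units; within the scatter) at a different place in the molecule, also lies within the scatter, so neither of the two single changes read so far separates a pair of compounds in this assay, and no information on what might lie behind these numbers is available.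

Open, going by these compounds, is whether a group of another kind on this oxygen, such as a plain methyl, a longer alkyl chain or an ether chain ending in an amine or a carboxylic acid, would give a step beyond the scatter. For the compounds shown here, also open is whether 1,1,2,2-tetrafluoroethyl behaves the same way on the other substitution patterns of the shared core, since its step rests on the single pair of compound 2 and compound 4.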